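Replacing the 2-methoxyphenyl group of compound 3 with 3-bromophenyl

This account rests on a few compounds, and the source may have more. Where it says the series, first, only, none or still open, it means among the compounds named here.

In a functional assay on A549 cells (Homo sapiens) for inhibition, read by MTT assay, with a stated time of 24 h (on this read-out higher numbers stand for weaker inhibition of growth and lower numbers for stronger inhibition of growth), compound 1 `COc1ccccc1C(=O)n1c(-c2cn(C)c3ccccc23)nc2ccccc21` gives 12300 nM and compound 2 `COc1cc(C(=O)n2c(-c3cn(C)c4ccccc34)nc3ccccc32)cc(OC)c1OC` gives 2600 nM while compound 3 `COc1ccc2c(c1)c(-c1nc3ccccc3n1C(=O)c1ccccc1OC)cn2C` gives 11900 nM and so sits with compound 1 at the high end of the three numbers, with compound 2 lower beyond the scatter. Going by the values given here, compound 4 `COc1ccc2c(c1)c(-c1nc3ccccc3n1C(=O)c1cccc(Br)c1)cn2C` carries 3-bromophenyl in place of 2-methoxyphenyl on a carbonyl carbon and no measured step covers this change. Among the compounds with values here, the one measured step of a 1.0-fold lower number from compound 1 to compound 3 (0.01 log units; within the scatter) is a different change within the scatter, so it offers little guidance. The lower value of compound 2 at 2600 nM only leaves room for a fall. The expected change is small, a 1.7-fold lower number from compound 3 to compound 4 (0.23 log units; within the scatter) and not clearly beyond the scatter. For compound 4 the estimate is 7000 nM with 2500 nM to 19000 nM as the expected range.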

Compound 4, concentration for 50% growth inhibition: 24800 nM
The estimate for compound 4 lay 3.5-fold (0.55 log units) below the measured number; the measured number lies above the stated range.
By their numbers in this assay, from the lowest: compound 2; then compounds 3, 1 and 4 (each within the scatter of the next, the first and the last beyond it).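

In this assay, exchanging 2-methoxyphenyl for 3-bromophenyl on the carbonyl carbon gives a 2.1-fold higher number from compound 3 to compound 4 (0.32 log units; beyond the scatter) and so a modest loss of growth inhibition. This is the first step shown at this position, and unlike the methoxy step elsewhere on the molecule, it lies beyond the scatter, so the group on this carbonyl carbon can move the number. Nothing available explains this step.

The compounds shown leave open whether the bromine itself or the loss of the methoxy group sets the size of the step. They also leave open how an amine or a carboxylic acid on this phenyl ring would read.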